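Methoxy in Place of Chloro on the Acid-Bearing Ring

A few compounds are considered here, and "the series" means these few. Any claim that something is new, unique, unknown or untested is made for them only; others in the source may bear on it.

Three measured compounds share one core. Compound 1 `Cc1cc(OC[C@H](C)COc2ccc(C(=O)CC(C)(C)C)c(O)c2C)ccc1C(=O)O` gives 1350 nM in an assay for positive allosteric modulation of metabotropic glutamate receptor 3 (Rattus norvegicus); a higher number here means that more compound is needed for the effect, a lower number that less compound is needed. Compound 2 `Cc1c(OC[C@@H](C)COc2ccc(C(=O)O)c(F)c2)ccc(C(=O)CC(C)(C)C)c1O` gives 1090 nM in this assay, and compound 3 `Cc1c(OC[C@@H](C)COc2ccc(C(=O)O)c(Cl)c2)ccc(C(=O)CC(C)(C)C)c1O` gives 860 nM. Compound 3 has the lowest of the three numbers, yet the gap a 1.3-fold lower number from compound 2 to compound 3 (0.10 log units; within the scatter) and the gap a 1.6-fold lower number from compound 1 to compound 3 (0.20 log units; within the scatter) both stay within the scatter. Compound 4 `COc1cc(OC[C@H](C)COc2ccc(C(=O)CC(C)(C)C)c(O)c2C)ccc1C(=O)O` carries methoxy in place of chloro on an aromatic carbon. For the measured compounds named here, no measured step exchanges chloro for methoxy; the steps that touch this position, a 1.2-fold lower number from compound 1 to compound 2 (0.09 log units; within the scatter), a 1.6-fold lower number from compound 1 to compound 3 (0.20 log units; within the scatter) and a 1.3-fold lower number from compound 2 to compound 3 (0.10 log units; within the scatter), all remained within the scatter. One therefore expects no step beyond the scatter for compound 4, a 1.2-fold higher number from compound 3 to compound 4 (0.07 log units; within the scatter). Compound 4 is estimated at 1000 nM, between 450 nM and 2300 nM.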

Compound 4, half-maximal effective concentration: 1460 nM
For compound 4 the middle estimate is 1.5-fold (0.16 log units) below the measured one, within the range that was stated.
By their numbers in this assay, from the lowest: compounds 3, 2, 1 and 4 (each within the scatter of the next).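

Methoxy brings a hydrogen-bond acceptor where chloro has none, ortho to a carboxy group, and in this assay the new steps all stay within the scatter: (a 1.7-fold higher number from compound 3 to compound 4 (0.23 log units; within the scatter)) and (a 1.3-fold higher number from compound 2 to compound 4 (0.13 log units; within the scatter)) and (a 1.1-fold higher number from compound 1 to compound 4 (0.03 log units; within the scatter)). Across methyl, fluoro, chloro and methoxy, this position therefore shows no step beyond the scatter. Nothing available explains why these groups read alike. On these data alone, whether an amine or a trifluoromethyl group here would also stay within the scatter remains open.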